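Extending the pyrimidine substituent: from methyl to 2-methoxyethoxy

A few compounds are considered here, and "the series" means these few. Any claim that something is new, unique, unknown or untested is made for them only; others in the source may bear on it.

Measured compounds:
compound 1, `CCOc1ncc(-c2nc(C(F)(F)F)sc2N2CCN(C(=O)Cn3cnc4cccnc43)[C@H](C)C2)cn1`, 48 nM
compound 2, `Cc1ncc(-c2nc(C(F)(F)F)sc2N2CCN(C(=O)Cn3cnc4cccnc43)[C@H](C)C2)cn1`, 104 nM

Of the compounds shown here, two sharing one core have been measured in an assay on blood for inhibition of C-X-C chemokine receptor type 3 (Homo sapiens), with a stated time of 30 min; a lower number here means a stronger inhibitor, a higher number a weaker inhibitor. Compound 1 gives 48 nM. Among the compounds with values here, compound 2 gives 104 nM, the higher of the two numbers, and the single step between them, methyl in place of ethoxy on an aromatic carbon, reads a 2.2-fold higher number from compound 1 to compound 2 (0.34 log units; beyond the scatter).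

Compound 3, `COCCOc1ncc(-c2nc(C(F)(F)F)sc2N2CCN(C(=O)Cn3cnc4cccnc43)[C@H](C)C2)cn1`, is not yet measured. It differs from compound 2 in one place: 2-methoxyethoxy in place of methyl on an aromatic carbon. Within the data shown here, the only step that bears on this change is the one from compound 1 to compound 2, where an ethoxy group was traded for methyl and the number rose modestly. Compound 3 restores an alkoxy group at the same aromatic carbon, longer than ethoxy by the atoms counted above, so the step is expected to run back in the other direction, roughly by the size of a 2.2-fold higher number from compound 1 to compound 2 (0.34 log units; beyond the scatter), and is estimated as a 1.9-fold lower number from compound 2 to compound 3 (0.28 log units; within the scatter). Compound 3 is therefore expected to give about 55 nM in this assay, within a range of 25 nM to 130 nM.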

Compound 3, half-maximal inhibitory concentration: 182 nM
The estimate for compound 3 lay 3.3-fold (0.52 log units) below the measured number, outside the stated range (above it).
By their numbers in this assay, from the lowest: compound 1; then compounds 2 and 3 (each within the scatter of the next).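

In this assay, the added methoxy on the ethoxy chain is not neutral: a 3.8-fold higher number from compound 1 to compound 3 (0.58 log units; beyond the scatter). An oxygen on the aromatic carbon, between two ring nitrogen atoms, is therefore not enough on its own to keep the number of compound 1, and what lies further out along the chain also counts. The 2-methoxyethoxy group, with 5 heavy atoms and 2 hydrogen-bond acceptors, is also not separated from the methyl group, with 1 heavy atom and no acceptors, since the step reads a 1.8-fold higher number from compound 2 to compound 3 (0.24 log units; within the scatter), and no evidence is at hand to explain this result.

The three compounds leave open whether the lower number of compound 1 is particular to ethoxy or extends to other small groups at this carbon, such as methoxy, propoxy or cyclopropoxy. They also leave open how the chain responds to a different end group, such as a 2-hydroxyethoxy chain or a 2-(dimethylamino)ethoxy chain, and whether a longer chain ending in a methoxy group would follow compound 3.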